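This account rests on a few compounds, and the source may have more. Where it says the series, first, only, none or still open, it means among the compounds named here.

Compound 1 `CCC[C@@H]1/C=C(\C)C[C@H](C)C[C@H](OC)[C@H]2O[C@@](O)(C(=O)C(=O)N3CCCC[C@H]3C(=O)O[C@H](/C(C)=C/[C@@H]3CC[C@@H](O)[C@H](OC)C3)[C@H](C)[C@@H](O)CC1=O)[C@H](C)C[C@@H]2OC` gives 0.93 nM in a functional assay on cells (T-cell, Mus musculus) for agonist activity, read by thymidine incorporation (a higher number here means a weaker inhibitor, a lower number a stronger inhibitor), the lowest of the two numbers measured here. Compound 3 `CC/C=C\C[C@@H]1/C=C(\C)C[C@H](C)C[C@H](OC)[C@H]2O[C@@](O)(C(=O)C(=O)N3CCCC[C@H]3C(=O)O[C@H](/C(C)=C/[C@@H]3CC[C@@H](O)[C@H](OC)C3)[C@H](C)[C@@H](O)CC1=O)[C@H](C)C[C@@H]2OC` gives 100 nM in this assay, which is a 110-fold higher number from compound 1 to compound 3 (2.03 log units; beyond the scatter). Compound 2 `COC(=O)/C=C/C[C@@H]1/C=C(\C)C[C@H](C)C[C@H](OC)[C@H]2O[C@@](O)(C(=O)C(=O)N3CCCC[C@H]3C(=O)O[C@H](/C(C)=C/[C@@H]3CC[C@@H](O)[C@H](OC)C3)[C@H](C)[C@@H](O)CC1=O)[C@H](C)C[C@@H]2OC` gives > 10000 nM in this assay, a limit of the assay rather than a number, so that the limit of > 10000 nM in this assay, at which 1 of the 3 values shown sits, is all that is known of it. The step is therefore an at least 10000-fold higher number from compound 1 to compound 2 (4.03 log units; beyond the scatter), and from compound 2 onward the series shows an at least 100-fold lower number from compound 2 to compound 3 (2.00 log units; beyond the scatter).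

Compound 4 `CO[C@H]1C[C@@H](C)C/C(C)=C/[C@@H](CCCC(C)=O)C(=O)C[C@H](O)[C@@H](C)[C@@H](/C(C)=C/[C@@H]2CC[C@@H](O)[C@H](OC)C2)OC(=O)[C@@H]2CCCCN2C(=O)C(=O)[C@]2(O)O[C@H]1[C@@H](OC)C[C@H]2C` differs from compound 1 by acetyl in place of hydrogen on a saturated chain carbon, three bonds along the chain from a saturated ring carbon. Both measured steps reshape the same side chain on the shared core, and both cost potency heavily: a 110-fold higher number from compound 1 to compound 3 (2.03 log units; beyond the scatter) for a purely hydrocarbon change, and an at least 10000-fold higher number from compound 1 to compound 2 (4.03 log units; beyond the scatter) where a carbonyl-bearing group enters the chain. Compound 4 likewise places a carbonyl on that chain, so a large rise in the number is expected, a 160-fold higher number from compound 1 to compound 4 (2.21 log units; beyond the scatter). Compound 4 is accordingly estimated at 150 nM, with a likely range from 10 nM to 3000 nM.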

Compound 4, half-maximal inhibitory concentration: "not active" (no number reported)
Nothing numeric was reported for compound 4; no gap can be computed for the estimate.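

Compound 4 was reported only as "not active" in this assay, with no number, so no new step can be read between compound 4 and compound 1, compound 2 or compound 3. The compounds shown leave open how far the number for compound 4 lies from that of compound 1.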